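This account rests on a few compounds, and the source may have more. Where it says the series, first, only, none or still open, it means among the compounds named here.

Measured in a functional assay on MKN-45 cells (Homo sapiens) for antiproliferative activity, read by MTT assay, with a stated time of 72 h; on this read-out higher numbers stand for weaker inhibition and lower numbers for stronger inhibition:
compound 1 `COc1cc(CCc2ccc(F)cc2)cc(OC)c1O` gives 10700 nM
compound 2 `COc1cc(CCc2ccc(Cl)cc2)cc(OC)c1O` gives a limit of the assay, > 25000 nM
compound 3 `COc1cc(CCc2ccc(Cl)cc2Cl)cc(OC)c1O` gives 4460 nM

Compound 1 carries the highest of the two actual numbers in this assay; compound 3 is nearest, with a lower number that lies beyond the scatter. Compound 2 is reported only as a limit (the limit of > 25000 nM in this assay, at which 1 of the 3 values shown sits), not as a number.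

Compound 4 `COc1cc(CCc2ccccc2)cc(OC)c1O` differs from compound 1 in one place: hydrogen in place of fluoro on an aromatic carbon. The group leaves an aromatic carbon of a six-membered aromatic ring of carbon only, para to a large group.

Among the measured compounds shown here, no measured step removes a halogen for hydrogen. The steps closest in kind are an at least 2.3-fold higher number from compound 1 to compound 2 (0.36 log units; beyond the scatter) and an at least 5.6-fold lower number from compound 2 to compound 3 (0.74 log units; beyond the scatter), both concerning chloro rather than fluoro, and the second running the opposite way, hydrogen to chloro. They show that a halogen at this part of the shared core shifts this assay by modest amounts in either direction, but neither tells which way loss of the fluoro will go. The step from compound 1 to compound 4 is therefore expected to stay near the scatter, with a slight lean toward a higher number, a 1.2-fold higher number from compound 1 to compound 4 (0.08 log units; within the scatter). For compound 4 the expected value in this assay is 13000 nM, within 5000 nM to 30000 nM.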

Compound 4, half-maximal inhibitory concentration: 1040 nM
Beside the measured number, compound 4's estimate is 13-fold (1.10 log units) above it, and the stated range ends above it.
By their numbers in this assay, from the lowest: compound 4; then compound 3; then compound 1. At a limit, above all of these: compound 2.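

In this assay, among the compounds shown here, removing the halogen para to a large group, on the six-membered aromatic ring of carbon only, gives the largest steps so far: hydrogen in place of fluoro gives a 10-fold lower number from compound 1 to compound 4 (1.01 log units; beyond the scatter), and hydrogen in place of chloro gives an at least 24-fold lower number from compound 2 to compound 4 (1.38 log units; beyond the scatter). Compound 2 stands as a limit and not as a number, so the second step is a minimum: the limit of > 25000 nM in this assay, at which 1 of the 4 values shown sits. The earlier steps shown here compared halogen with halogen, or added a chloro to a compound already carrying one, whereas these two steps set hydrogen directly against fluoro and against chloro at this position, and in both pairs hydrogen goes with the lower number.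

The compounds shown leave open whether other groups at this position, such as methyl, methoxy, an amine or a carboxylic acid, would also go with higher numbers than hydrogen. They also leave open whether the added chloro behind an at least 5.6-fold lower number from compound 2 to compound 3 (0.74 log units; beyond the scatter) would lower the number further on the core of compound 4, which has no chloro at this position.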